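The source may hold more compounds than are shown below. What is called first, only, known or untested is meant among the compounds shown, and "the series" means these compounds.

Measured so far in a functional assay on Raji cells (Homo sapiens) for antiproliferative activity, read by CCK-8 assay, with a stated time of 24 h; on this read-out higher numbers stand for weaker inhibition and lower numbers for stronger inhibition:
- compound 1 `C=CC(=O)Nc1cccc(Nc2ncnc(Nc3ccc(C(=O)Nc4ccccn4)cc3)n2)c1` gives 15600 nM
- compound 2 `C=CC(=O)Nc1cccc(Nc2ncnc(Nc3ccc(C(=O)Nc4ccc(C)cn4)cc3)n2)c1` gives 125000 nM
- compound 3 `C=CC(=O)Nc1cccc(Nc2ncnc(Nc3ccc(-c4cccnc4)cc3)n2)c1` gives 12400 nM

Compound 3 carries the lowest number of the three, though its gap to compound 1 sits within the scatter, so only compound 2 is clearly set apart. Compound 4 `C=CC(=O)Nc1cccc(Nc2ncnc(Nc3ccc(OCCOC)cc3)n2)c1` differs from compound 3 in one place: 2-methoxyethoxy in place of pyridin-3-yl on an aromatic carbon. Among the measured compounds shown here, no measured step swaps a ring for a chain at this position. The nearest guides are a 1.3-fold lower number from compound 1 to compound 3 (0.10 log units; within the scatter) and a 10-fold lower number from compound 2 to compound 3 (1.00 log units; beyond the scatter), which show that groups at this position can shift this assay by modest amounts at most. Compound 4 is therefore expected to stay close to compound 3, with a 1.3-fold higher number from compound 3 to compound 4 (0.11 log units; within the scatter). The estimate for compound 4 is 16000 nM, within a range from 5000 nM to 50000 nM.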

Compound 4, half-maximal inhibitory concentration: 105000 nM
Beside the measured number, compound 4's estimate is 6.6-fold (0.82 log units) below it; the whole stated range lies below it.
By their numbers in this assay, from the lowest: compounds 3 and 1 (each within the scatter of the next); then compounds 4 and 2 (each within the scatter of the next).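

Swapping the ring for an open chain at this position is not neutral: 2-methoxyethoxy in place of pyridin-3-yl gives an 8.5-fold higher number from compound 3 to compound 4 (0.93 log units; beyond the scatter) and so weaker inhibition, and the same group in place of (pyridin-2-yl)carbamoyl gives a 6.7-fold higher number from compound 1 to compound 4 (0.83 log units; beyond the scatter) in the same direction. In place of (5-methylpyridin-2-yl)carbamoyl it gives a 1.2-fold lower number from compound 2 to compound 4 (0.08 log units; within the scatter) and so no real difference. Nothing available explains these shifts.

Still open, going by these compounds, is whether a shorter methoxy group, a longer chain or a chain ending in an amine would match 2-methoxyethoxy or come closer to pyridin-3-yl.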